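Trading an isopropyl for a hydroxyethylamino group

The source may hold more compounds than are shown below. What is called first, only, known or untested is meant among the compounds shown, and "the series" means these compounds.

This account follows the step from compound 2 to compound 4 in an assay on microsomes for inhibition of acyl-CoA:cholesterol acyltransferase (Oryctolagus cuniculus); on this read-out lower numbers stand for stronger inhibition and higher numbers for weaker inhibition. Compound 2 `CC(C)c1ccc(C2(CNC(=O)Nc3c(C(C)C)cccc3C(C)C)CCCC2)cc1` gives 48 nM, the highest of the three numbers measured. Its nearest neighbour is compound 3 `CC(C)c1cccc(C(C)C)c1NC(=O)NCC1(c2ccc(Cl)cc2)CCCC1`, which gives 32 nM; the pair differs only by chloro in place of isopropyl on an aromatic carbon, and a 1.5-fold lower number from compound 2 to compound 3 (0.18 log units; within the scatter). Compound 1 `Cc1cccc(C2(CNC(=O)Nc3c(C(C)C)cccc3C(C)C)CCCC2)c1` gives 15 nM, and the steps from it are larger: a 3.2-fold higher number from compound 1 to compound 2 (0.51 log units; beyond the scatter) and a 2.1-fold higher number from compound 1 to compound 3 (0.33 log units; beyond the scatter).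

Compound 4 `CC(C)c1cccc(C(C)C)c1NC(=O)NCC1(c2ccc(NCCO)cc2)CCCC1` has not yet been measured. It differs from compound 2 by (2-hydroxyethyl)amino in place of isopropyl on an aromatic carbon. Going by the values given here, no measured step involves a group carrying hydrogen-bond donors or acceptors on this aromatic ring; the only change at this aromatic carbon, from compound 2 to compound 3, stayed within the scatter, and the other steps were modest. Compound 4 is therefore expected to give a somewhat higher number, a 2.5-fold higher number from compound 2 to compound 4 (0.40 log units; beyond the scatter), with wide uncertainty. The estimate for compound 4 is 120 nM, ranging from 40 nM to 400 nM.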

Compound 4, half-maximal inhibitory concentration: 25 nM
Estimate against measurement, compound 4: 4.8-fold (0.68 log units) above; measured number outside the range, below it.
By their numbers in this assay, from the lowest: compounds 1, 4, 3 and 2 (each within the scatter of the next, the first and the last beyond it).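

In this assay, this aromatic carbon takes a group carrying hydrogen-bond donors and acceptors, which isopropyl lacks, and the swap gives a 1.9-fold lower number from compound 2 to compound 4 (0.28 log units; within the scatter) while the swap from chloro gives a 1.3-fold lower number from compound 3 to compound 4 (0.11 log units; within the scatter) so neither change leaves the scatter. The step away from the 3-methylphenyl group, which had been beyond the scatter for the two earlier compounds, now gives a 1.7-fold higher number from compound 1 to compound 4 (0.22 log units; within the scatter) and so also stays within it. Nothing among the data shown bears on what lies behind this result.

As far as these compounds go, it remains open whether a carboxylic acid, a simple primary amine or a longer hydroxyalkylamino chain would be taken up at this carbon as readily. The compounds shown also do not separate the contribution of the chain's hydroxyl from that of its amine nitrogen.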